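The compounds below may be only part of what the source reports. "The series", "measured", "known", "first", "only" and "open" are said of these compounds alone.

Compound 3 `CC(CCNC(=O)c1c(Cl)cncc1Cl)N1CCC(C(Oc2cccc(C#N)n2)c2ccc(C(F)(F)F)cc2)CC1` gives 15700 nM in an ADME assay on PBMC cells (Homo sapiens) for cytotoxicity (on this read-out higher numbers stand for lower toxicity in this test and lower numbers for higher toxicity in this test), the highest of the two numbers seen in this assay, while compound 1 `CC(CCNC(=O)c1c(Cl)cncc1Cl)N1CCC(C(Oc2cccc(C(F)(F)F)c2)c2ccc(C(F)(F)F)cc2)CC1` gives 7000 nM. Compound 2 `CC(CCNC(=O)c1c(Cl)cncc1Cl)N1CCC(C(Oc2cccc(Cl)n2)c2ccc(C(F)(F)F)cc2)CC1` reaches only a limit of the assay, > 32500 nM. Compound 4 `CC(CCNC(=O)c1c(Cl)cncc1Cl)N1CCC(C(Oc2cccc(F)c2)c2ccc(C(F)(F)F)cc2)CC1` has not yet been measured; it differs from compound 3 by 3-fluorophenyl in place of 6-cyanopyridin-2-yl on an oxygen on a saturated carbon. The step that bears most on this is a 2.2-fold higher number from compound 1 to compound 3 (0.35 log units; beyond the scatter), which put 6-cyanopyridin-2-yl in place of 3-(trifluoromethyl)phenyl; compound 4 reverses that kind of exchange, returning to a phenyl ring, so a modest lower number is expected, a 2.0-fold lower number from compound 3 to compound 4 (0.29 log units; within the scatter). Compound 4 is therefore estimated at 8000 nM, with a range from 3500 nM to 18000 nM.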

Compound 4, half-maximal cytotoxic concentration: 5400 nM
Beside the measured number, compound 4's estimate is 1.5-fold (0.17 log units) above it; the measured number falls inside the stated range.
By their numbers in this assay, from the lowest: compounds 4 and 1 (each within the scatter of the next); then compound 3. At a limit, above all of these: compound 2.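

In this assay, changing the substituent on the phenyl ring makes no difference beyond the scatter: a 1.3-fold lower number from compound 1 to compound 4 (0.11 log units; within the scatter). Going from 6-cyanopyridin-2-yl to 3-fluorophenyl gives a 2.9-fold lower number from compound 3 to compound 4 (0.46 log units; beyond the scatter), so among these four compounds the higher numbers go with the pyridine rings, whichever phenyl substituent is compared. From 6-chloropyridin-2-yl, the exchange gives an at least 6.0-fold lower number from compound 2 to compound 4 (0.77 log units; beyond the scatter), a size that is only a bound, as compound 2 stands at a limit: the limit of > 32500 nM in this assay, at which 1 of the 4 values shown sits.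

Going by these compounds, it remains open whether the ring nitrogen alone goes with the higher numbers, or whether the cyano and chloro groups also contribute. A 3-cyanophenyl or an unsubstituted pyridin-2-yl group on this oxygen would separate the two.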